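Adding a Formyl Group Beside an Existing Nitrile

The source may hold more compounds than are shown below. What is called first, only, known or untested is meant among the compounds shown, and "the series" means these compounds.

Measured so far:
compound 1 `O=Cc1c(-c2ccccc2)sc2ccccc12` — 51%
compound 2 `N#Cc1ccccc1-c1cc2ccccc2s1` — 49%

In a functional assay on MCF7 cells (Homo sapiens) for cytotoxicity, tested at 10 uM (a lower number here means less inhibition, a higher number more inhibition at the concentration tested (going by the name of the read-out)), compound 1 gives 51%. In the same assay compound 2 gives 49%. The two values lie within the usual scatter of one another, so the measurements so far do not separate the two compounds at all.

Compound 3 `N#Cc1ccccc1-c1sc2ccccc2c1C=O` has not yet been measured. It differs from compound 2 in one place:

formyl in place of hydrogen on an aromatic carbon

Compound 1 already carries a formyl group on the shared core, while compound 2 does not, and in this assay their values are indistinguishable. Going by the values given here, there is no measured pair differing in just one place, so no measured size of a step is available to lean on. What the numbers do show is that presence or absence of the formyl group, on these two compounds, made no visible difference. The step expected here is therefore a number 1 percentage points higher from compound 2 to compound 3 (within the scatter), that is, none beyond the scatter in either direction.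

Compound 3 is thus expected to give 50% in this assay, with a likely range from 32% to 68%.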

Compound 3, a percentage reported as inhibition, at one concentration (the size of the read-out at that concentration, not a potency): 38%
Compound 3: middle estimate off by 12 percentage points, on the high side; the range from low to high includes it.
By their numbers in this assay, from the lowest: compound 3; then compounds 2 and 1 (each within the scatter of the next).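

Measured in this assay, a single change at this position now has a size: formyl in place of hydrogen on an aromatic carbon of the five-membered aromatic ring with 1 sulfur gives a number 11 percentage points lower from compound 2 to compound 3 (beyond the scatter), so with the nitrile present the read-out responds to what sits on this carbon. The other single change points the same way, as bringing in the nitrile gives a number 13 percentage points lower from compound 1 to compound 3 (beyond the scatter), which places compound 3, carrying both groups, lower than each compound that carries only one of them. Nothing available explains why the two groups together go with a lower number.

From the compounds shown here alone, it remains open whether this step belongs to formyl itself or would follow other groups on the same carbon, such as an amine, a carboxylic acid or a longer chain. Also open, going by these compounds, is whether formyl would give any such step on a core without the nitrile, and how these steps would look as potencies rather than as readings at a single concentration.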